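This account rests on a few compounds, and the source may have more. Where it says the series, first, only, none or still open, it means among the compounds named here.

Working notes on the series in a functional assay on MDA-MB-468 cells (Homo sapiens) for inhibition, read by sulforhodamine B assay, with a stated time of 48 h; on this read-out lower numbers stand for higher toxicity in this test and higher numbers for lower toxicity in this test. Compound 1 `O=C(Nc1cccc(-n2cc(-c3ccncc3)c(-c3ccc(Cl)c(O)c3)n2)c1)Nc1cccc(C(F)(F)F)c1` gives only a limit there, > 32500 nM, not a number. In this assay, going by the values given here, compound 2 `COc1cc(-c2nn(-c3cccc(NC(=O)Nc4cc(C(F)(F)F)cc(C(F)(F)F)c4)c3)cc2-c2ccncc2)ccc1Cl` gives 24300 nM, the one number so far. Of the two values shown, one is thus a measured figure and the other the limit of > 32500 nM in this assay, at which 1 of the 2 values shown sits, belongs to compound 1. Compound 3 `O=C(Nc1cccc(-n2cc(-c3ccncc3)c(-c3ccc(Cl)c(O)c3)n2)c1)Nc1cc(C(F)(F)F)cc(C(F)(F)F)c1` has not been run. It differs from compound 2 by hydrogen in place of methyl on an oxygen on an aromatic ring, a change that read one bond further out is methoxy to hydroxy, 4-chloro-3-methoxyphenyl to 4-chloro-3-hydroxyphenyl. Among the compounds with values here, no measured pair shows this step on its own, so no size can be taken from the data; compound 1, which also carries the hydroxy group, sits at the limit. The step from compound 2 to compound 3 is expected to be small, a 1.2-fold higher number from compound 2 to compound 3 (0.09 log units; within the scatter), within the scatter or toward lower toxicity. Compound 3 is expected to give about 30000 nM, with a range from 12000 nM to 70000 nM, and a fair chance that this assay reports only a limit.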

Compound 3, concentration lethal to 50% of the cells: 37100 nM
Compound 3: the middle estimate sits 1.2-fold (0.09 log units) below what was measured, and the stated range covers the measured number.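

The methoxy to hydroxy change on 4-chloro-3-methoxyphenyl now has a measured size in this assay, which shows a 1.5-fold higher number from compound 2 to compound 3 (0.18 log units; within the scatter). On this evidence, hydrogen and methyl on this oxygen on an aromatic ring cannot be told apart in this test, at least with the core and urea substituents of these two compounds. Compound 1 remains a limit and not a number, so the step from it to compound 3, trifluoromethyl in place of hydrogen on an aromatic carbon, cannot be read: the limit of > 32500 nM in this assay, at which 1 of the 3 values shown sits.

As far as these compounds go, it remains open whether a longer chain such as ethoxy, or an amine in place of the hydroxy group, would separate from these two groups. From the compounds shown here alone, the size of the trifluoromethyl step also stays open until both of its compounds carry a number.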